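Thiourea ether series: cytotoxicity and the terminal aryl group

A few compounds are considered here, and "the series" means these few. Any claim that something is new, unique, unknown or untested is made for them only; others in the source may bear on it.

Compound 1 `NC(=S)Nc1cccc(OCCCCCOc2ccc(Cl)cc2)c1` gives 7000 nM in an ADME assay on Ava5 cells (Homo sapiens) for cytotoxicity; a higher number here means that more compound is tolerated, a lower number that less compound is tolerated. Compound 2 `COc1ccc(OCCCCCOc2cccc(NC(N)=S)c2)cc1` returns only the limit of this assay, > 50000 nM. Compound 3 `NC(=S)Nc1cccc(OCCCCCOc2ccc(-c3ccccc3)cc2)c1` likewise returns only the limit, > 50000 nM. The step of an at least 7.1-fold higher number from compound 1 to compound 2 (0.85 log units; beyond the scatter) and the step of an at least 7.1-fold higher number from compound 1 to compound 3 (0.85 log units; beyond the scatter) both point the same way, whereas the step that the two limits leave unreadable from compound 2 to compound 3 cannot be read due to the limit of > 50000 nM in this assay, at which 2 of the 3 values shown sit. Compound 3 therefore stands at the upper edge of the numbers shown, alongside compound 2, with compound 1 the only compound below that edge.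

Compound 4 `NC(=S)Nc1cccc(OCCCCCOc2ccc(-n3cccc3)cc2)c1` differs from compound 3 by 1H-pyrrol-1-yl in place of phenyl on an aromatic carbon. For the measured compounds named here, no measured step exchanges one terminal aromatic ring for another, so the only steps that bear on this position are those leaving chloro, and both of them end at the limit. In this assay compound 4 is expected to remain near the limit, and the step of an at least 1.2-fold lower number from compound 3 to compound 4 (0.09 log units; that floor lies within the scatter) is expected to stay within the scatter. The estimate for compound 4 is 40000 nM, with a range from 12000 nM to 120000 nM.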

Compound 4, half-maximal cytotoxic concentration: > 50000 nM
Compound 4: only a limit was reported; the forecaster's own chance of this, stated with the estimate: 60%; middle value at least 1.2-fold (0.09 log units) from the limit.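

Compound 4 returns a limit in this assay, > 50000 nM, and not a number. The exchange of chloro for 1H-pyrrol-1-yl gives an at least 7.1-fold higher number from compound 1 to compound 4 (0.85 log units; beyond the scatter), so a five-membered aromatic ring with 1 hetero atom joins methoxy and phenyl as a third replacement for chloro that ends at the limit, and compound 1 remains the only compound shown with a number under it. The steps among compound 2, compound 3 and compound 4 cannot be read, so no order among these groups can be given: the limit of > 50000 nM in this assay, at which 3 of the 4 values shown sit.

Open, as far as these compounds go, is whether the lower number belongs to chloro alone or also appears with bromo or trifluoromethyl at this position. Also open, from the compounds shown here alone, is whether an amine or a carboxylic acid here, or a longer chain in the linker, would bring the number under the limit.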